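Methyl for Methoxy on the Pyrimidine of Compound 2

The source may hold more compounds than are shown below. What is called first, only, known or untested is meant among the compounds shown, and "the series" means these compounds.

Measured compounds:
compound 1, `COc1cc(C)nc2n/c(=N/C(=O)c3c(-c4ccc(Cl)cc4Cl)noc3C)sn12`: 50.3%
compound 2, `COc1cc(SC)nc(NC(=S)NC(=O)c2c(-c3ccc(Cl)cc3Cl)noc2C)n1`: 34.8%

In a functional assay on the whole organism for inhibition, with Digitaria ciliaris as the target, with a stated time of 72 h, tested at 10 mg/L (on this read-out higher numbers stand for more inhibition of growth at the one concentration tested and lower numbers for less inhibition of growth), compound 1 gives 50.3%. Compound 2 gives 34.8%, the lower of the two numbers, and the gap to compound 1 lies beyond the usual scatter. Among the compounds with values here, no pair of the measured compounds differs in a single place, so no measured step can guide the next change.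

Compound 3, `CSc1cc(C)nc(NC(=S)NC(=O)c2c(-c3ccc(Cl)cc3Cl)noc2C)n1`, carries the change (methyl in place of methoxy on an aromatic carbon), that is, methyl in place of methoxy on an aromatic carbon. Within the data shown here, with no comparable step among the measured compounds, the size of this change is open. The step is estimated as a number 0.2 percentage points higher from compound 2 to compound 3 (within the scatter), expected to stay within the scatter in either direction. Compound 3 is therefore expected to give about 35% in this assay, within a range from 15% to 55%.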

Compound 3, percent growth inhibition at one concentration: 26.7%
For compound 3 the middle estimate is 8.3 percentage points above the measured one, and the stated range covers the measured number.
By their numbers in this assay, from the lowest: compounds 3 and 2 (each within the scatter of the next); then compound 1.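

In this assay, within the data shown here, compounds 2 and 3 give the first step in one place, a number 8.1 percentage points lower from compound 2 to compound 3 (within the scatter), so the two compounds cannot be told apart by this read-out. At this position, next to the ring nitrogen and meta to the methylsulfanyl group, the methoxy group with its one hydrogen-bond acceptor can give way to methyl without a change beyond the scatter at the one concentration tested. Nothing available offers an explanation for this result beyond the numbers themselves. Going by these compounds, whether an amine, an ethoxy group or a longer chain on this carbon would give a different reading remains open. So does what an exchange of the methylsulfanyl group would do, and no single-place step yet connects compound 1 to the other two compounds.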